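Changing the Amide Side Chain of Compound 3

The source may hold more compounds than are shown below. What is called first, only, known or untested is meant among the compounds shown, and "the series" means these compounds.

Values in a functional assay on BXPC-3 cells (Homo sapiens) for antiproliferative activity, read by MTT assay, with a stated time of 24 h (a lower number here means a stronger inhibitor, a higher number a weaker inhibitor), are as follows
compound 1 `CCn1c(C(=O)N[C@@H](C)C(=O)OC)ccc1C(CC)(CC)c1ccc(OCS(=O)(=O)c2ccccc2)c(C)c1` gives 17900 nM
compound 2 `CCn1c(C(=O)N[C@@H](C)CO)ccc1C(CC)(CC)c1ccc(OCS(=O)(=O)c2ccccc2)c(C)c1` gives 15300 nM
compound 3 `CCn1c(C(=O)NC(C)(C)CO)ccc1C(CC)(CC)c1ccc(OCS(=O)(=O)c2ccccc2)c(C)c1` gives 18300 nM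

At 18300 nM, compound 3 stands level with compound 1 and compound 2, all three within the scatter. Compound 4 `CCn1c(C(=O)N[C@H](CO)CCO)ccc1C(CC)(CC)c1ccc(OCS(=O)(=O)c2ccccc2)c(C)c1` carries 3-hydroxy-1-(hydroxymethyl)propyl in place of 1-(hydroxymethyl)-1-methylethyl on an amide-type nitrogen. Three measured steps change the same side chain: a 1.2-fold lower number from compound 1 to compound 2 (0.07 log units; within the scatter), a 1.0-fold higher number from compound 1 to compound 3 (0.01 log units; within the scatter) and a 1.2-fold higher number from compound 2 to compound 3 (0.08 log units; within the scatter). All lie within the scatter, so no step beyond it is expected in this assay, though none of them introduces the entering chain. The expected step is a 1.1-fold lower number from compound 3 to compound 4 (0.03 log units; within the scatter). Compound 4 is estimated at 17000 nM, with an expected range from 9000 nM to 30000 nM.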

Compound 4, half-maximal inhibitory concentration: 15900 nM
The estimate for compound 4 lay 1.1-fold (0.03 log units) above the measured number; measured number inside the range.
By their numbers in this assay, from the lowest: compounds 2, 4, 1 and 3 (each within the scatter of the next).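

Placing hydroxymethyl in place of hydrogen on the chain leaves the reading in this assay level, with a 1.0-fold higher number from compound 2 to compound 4 (0.02 log units; within the scatter). The comparisons with the other two chains agree, with a 1.2-fold lower number from compound 3 to compound 4 (0.06 log units; within the scatter) and a 1.1-fold lower number from compound 1 to compound 4 (0.05 log units; within the scatter), so all four chains on the amide-type nitrogen read alike within the scatter, now including one with 2 hydrogen-bond donors. No available evidence accounts for this sameness. On these data alone, whether an amine, a carboxylic acid or a longer chain at this position would depart from that level stays open, as does the role of the defined stereocentre in compound 4.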